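The compounds below may be only part of what the source reports. "The series", "measured", "known", "first", "only" and "open" are said of these compounds alone.

Of the compounds shown here, two have so far been measured in a functional assay on A549 cells (Homo sapiens) for antiproliferative activity, read by MTT assay, with a stated time of 24 h; on this read-out lower numbers stand for stronger inhibition and higher numbers for weaker inhibition. Compound 1 (`FC(F)(F)c1ccc(-c2nn(-c3ccccc3)cc2-c2nc3ccccc3[nH]2)cc1`) gives 3620 nM, and compound 2 (`O=S(=O)(c1ccccc1)n1c(-c2cn(-c3ccccc3)nc2-c2ccc(F)cc2)nc2ccccc21`) gives 550 nM. Compound 2 therefore holds the lower of the two numbers, and its gap to compound 1 lies beyond the usual scatter of repeated measurements.

Compound 3 (`O=S(=O)(c1ccccc1)n1c(-c2cn(-c3ccccc3)nc2-c2ccc(C(F)(F)F)cc2)nc2ccccc21`) has not yet been measured. It departs from compound 2 in a single place, with trifluoromethyl in place of fluoro on an aromatic carbon, para to a large group: trifluoromethyl in place of fluoro on an aromatic carbon. Within the data shown here, the data contain no matched pair for this change. Compound 1 also carries the 4-(trifluoromethyl)phenyl group, but it differs from compound 3 elsewhere as well, so its value cannot isolate the effect of this exchange.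

Among the measured compounds shown here, with no measured step to draw on, no shift beyond the scatter is expected in this assay, and no firm direction can be assigned. The expected change is a 1.1-fold higher number from compound 2 to compound 3 (0.04 log units; within the scatter). For compound 3 the estimated value is 600 nM, with an expected range from 200 nM to 1600 nM.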

Compound 3, half-maximal inhibitory concentration: 480 nM
The estimate for compound 3 lay 1.3-fold (0.10 log units) above the measured number; the measured number falls inside the stated range.
By their numbers in this assay, from the lowest: compounds 3 and 2 (each within the scatter of the next); then compound 1.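

In this assay, trifluoromethyl in place of fluoro on an aromatic carbon, para to a large group, gives a 1.1-fold lower number from compound 2 to compound 3 (0.06 log units; within the scatter) and so leaves the value within the scatter, which shows that with phenylsulfonyl on the aromatic nitrogen this position accepts four heavy atoms as readily as one. Phenylsulfonyl in place of hydrogen on that nitrogen gives a 7.5-fold lower number from compound 1 to compound 3 (0.88 log units; beyond the scatter) with the 4-(trifluoromethyl)phenyl group held constant, the first single-place step in this series to lie beyond the scatter, so the change at the nitrogen moves the number while the exchange at the aromatic carbon does not. No measurement at hand bears on what lies behind either step.

From the compounds shown here alone, both groups at the aromatic carbon contain fluorine, so it remains open whether a methoxy group, an amine or a carboxylic acid there would keep the number in the same range. Going by these compounds, each step also rests on a single pair, so it is equally open whether the phenyl part of the phenylsulfonyl group matters or whether a methylsulfonyl or an acetyl group on the nitrogen would give a similar step.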